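This account rests on a few compounds, and the source may have more. Where it says the series, first, only, none or still open, it means among the compounds named here.

Measured compounds:
- compound 2, `Oc1ccc(-c2cc(-c3ccc(Cl)cc3)nc(-c3ccsc3)c2)cc1`: 6940 nM
- compound 1, `Oc1ccc(-c2cc(-c3ccccn3)nc(-c3ccccc3Cl)c2)cc1`: "not determined" (no result reported)

Going by the values given here, compound 2 is the only compound of this pair with a number in a functional assay on DU-145 cells (Homo sapiens) for cytotoxicity, read by CCK-8 assay and cell counting, with a stated time of 2 days; a higher number here means a weaker inhibitor, a lower number a stronger inhibitor. In this assay compound 2 gives 6940 nM, and compound 1 has no result in this assay, so compound 2 stands alone and cannot be placed against any other measured value. Among the compounds with values here, no step between measured compounds is known.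

Compound 3, `Oc1ccc(-c2cc(-c3ccc(Cl)cc3)nc(-c3ccccn3)c2)cc1`, differs from compound 2 in one place: pyridin-2-yl in place of thiophen-3-yl on an aromatic carbon. Within the data shown here, with no measured step to lean on, and only a single value from compound 2 to start from, the change is expected to move the result by no more than the usual scatter in either direction. Compound 3 is therefore estimated at 7000 nM, with a range from 2500 nM to 20000 nM, which means an expected step of a 1.0-fold higher number from compound 2 to compound 3 (0.00 log units; within the scatter).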

Compound 3, half-maximal inhibitory concentration: 22500 nM
For compound 3 the middle estimate is 3.2-fold (0.51 log units) below the measured one, outside the stated range (above it).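

In this assay, replacing thiophen-3-yl with pyridin-2-yl gives a 3.2-fold higher number from compound 2 to compound 3 (0.51 log units; beyond the scatter), so the position next to the ring nitrogen responds to the group it carries, and here the higher number means a weaker inhibitor. The step is a swap of one aromatic ring for another, each with a single hetero atom, and it leaves the counted hydrogen-bond donors and acceptors unchanged, yet the number still moves beyond the scatter. No measurement at hand explains why this exchange moves the result.

The compounds shown do not tell how this position would respond to a group other than an aromatic ring, such as an amine, a carboxylic acid or a longer alkyl chain. They also leave open whether a plain phenyl ring here would fall on either side of these two values, and how much the 4-chlorophenyl and 4-hydroxyphenyl groups contribute.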